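This account rests on a few compounds, and the source may have more. Where it says the series, first, only, none or still open, it means among the compounds named here.

Measured in a functional assay (aorta) with Rattus norvegicus as the target; on this read-out higher numbers stand for weaker inhibition and lower numbers for stronger inhibition:
- compound 1 `CCN(CC)CCCOc1ccc(S(=O)(=O)c2c(C)cn3ccccc23)cc1`: 3390 nM
- compound 2 `CCCCCN(CCCCC)CCCOc1ccc(S(=O)(=O)c2c(C(C)C)cn3ccccc23)cc1`: 89.6 nM
- compound 3 `COc1ccc(CN(C)CCCOc2ccc(S(=O)(=O)c3c(C(C)C)cn4ccccc34)cc2)cc1OC`: 3.18 nM

Compound 2 holds the middle of these three numbers, with compound 3 lower and compound 1 higher, both gaps beyond the scatter. Compound 4 `COc1ccc(NCCCOc2ccc(S(=O)(=O)c3c(C(C)C)cn4ccccc34)cc2)cc1OC` has not yet been measured. It carries (3,4-dimethoxyphenyl)amino in place of dipentylamino on a saturated chain carbon, three bonds along the chain from an oxygen on an aromatic ring. Going by the values given here, no measured pair isolates this change, so the expectation rests on compound 3, which also holds a 3,4-dimethoxyphenyl group and gives 3.18 nM. A modest downward step, beyond the scatter, is therefore expected, and the estimate is a 3.6-fold lower number from compound 2 to compound 4 (0.55 log units; beyond the scatter). For compound 4 the estimated value is 25 nM, with an expected range from 5 nM to 120 nM.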

Compound 4, half-maximal inhibitory concentration: 396 nM
Estimate against measurement, compound 4: 16-fold (1.20 log units) below; the measured number lies above the stated range.
By their numbers in this assay, from the lowest: compound 3; then compound 2; then compound 4; then compound 1.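

In this assay, going by these compounds alone, the first single-place step at this chain carbon is a 4.4-fold higher number from compound 2 to compound 4 (0.65 log units; beyond the scatter), so (3,4-dimethoxyphenyl)amino gives weaker inhibition than dipentylamino, although both groups hold the same number of heavy atoms. A 3,4-dimethoxyphenyl group at this place therefore does not assure a low number. Nothing available explains this step. The compounds shown leave open how a methyl group on the nitrogen of compound 4 would change its number. They also leave open the effect of (3,4-dimethoxybenzyl)amino in place of its (3,4-dimethoxyphenyl)amino.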